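Aryl-acetylene phenoxyacetic acids: chloro for isopropyl

The source may report more compounds than this note shows. Statements on the series, on what has been measured and on what is new or still open speak of the compounds shown alone.

Working notes on the shared core. In an assay on CHO cells for displacement of a labelled ligand from prostaglandin D2 receptor 2 (Homo sapiens), read by scintillation counting (a higher number here means a weaker inhibitor, a lower number a stronger inhibitor), compound 1 `CS(=O)(=O)c1cccc(C#Cc2cc(Cl)ccc2OCC(=O)O)c1` gives 15 nM, compound 2 `O=C(O)COc1ccc(Cl)cc1C#Cc1ccccc1Cl` gives 28 nM, and compound 3 `CC(C)c1ccc(S(C)(=O)=O)cc1C#Cc1cc(Cl)ccc1OCC(=O)O` gives 4.6 nM, the lowest number of the three. Among the compounds with values here, the one single-point step available, a 3.3-fold lower number from compound 1 to compound 3 (0.51 log units; beyond the scatter), ties the isopropyl to a modest drop beyond the scatter. Compound 4 `CS(=O)(=O)c1ccc(Cl)c(C#Cc2cc(Cl)ccc2OCC(=O)O)c1` differs from compound 3 by chloro in place of isopropyl on an aromatic carbon. Within the data shown here, only that earlier step bears on this change; it shows what the isopropyl added, but nothing measured shows what a chloro adds in its place. A chloro is expected to hold part of that drop, so compound 4 is estimated at 9 nM, between 4 nM and 25 nM, which would mean an expected step of a 2.0-fold higher number from compound 3 to compound 4 (0.29 log units; within the scatter).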

Compound 4, inhibition constant: 3.5 nM
Compound 4: the middle estimate sits 2.6-fold (0.41 log units) above what was measured; measured number below the stated range.
By their numbers in this assay, from the lowest: compounds 4 and 3 (each within the scatter of the next); then compounds 1 and 2 (each within the scatter of the next).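

In this assay, a single chlorine does as well as isopropyl at this position, para to a methylsulfonyl group: a 1.3-fold lower number from compound 3 to compound 4 (0.12 log units; within the scatter). Chloro in place of hydrogen also gives a step beyond the scatter, a 4.3-fold lower number from compound 1 to compound 4 (0.63 log units; beyond the scatter), and with that chloro present, methylsulfonyl in place of hydrogen gives an 8.0-fold lower number from compound 2 to compound 4 (0.90 log units; beyond the scatter). Nothing available explains why the two groups read alike.

Still open, going by these compounds, is whether a methoxy group or an amine at this position would keep the number as low as chloro and isopropyl do. On these data alone, the effect of a sulfonamide in place of the methylsulfonyl group is also open.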